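The source may report more compounds than this note shows. Statements on the series, on what has been measured and on what is new or still open speak of the compounds shown alone.

Series notes, the step from compound 2 to compound 3.

Compound 1 `COC(=O)[C@@]1(C)CCC=C2[C@@H]1CC[C@@H](C)[C@]2(C)Cc1c(C)[nH]c2ccccc12` gives 15000 nM in a functional assay on A549 cells (Homo sapiens) for inhibition, read by sulforhodamine B assay, with a stated time of 48 h; on this read-out higher numbers stand for weaker inhibition of growth and lower numbers for stronger inhibition of growth. Compound 2 `COC(=O)[C@@]1(C)CCC=C2[C@@H]1CC[C@@H](C)[C@]2(C)Cc1c(C)[nH]c2ccc(C)cc12` gives 26000 nM in this assay; on the two numbers in hand compound 2 has the higher one, with compound 1 nearest, and the step of a 1.7-fold higher number from compound 1 to compound 2 (0.24 log units; within the scatter) lies within the scatter of this assay, so no order between the two is established.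

Compound 3 `COC(=O)[C@@]1(C)CCC=C2[C@@H]1CC[C@@H](C)[C@]2(C)Cc1c(C)[nH]c2ccc(Br)cc12` is the next member: bromo in place of methyl on an aromatic carbon. Among the measured compounds shown here, no measured step covers a bromo-for-methyl exchange, and the one step available, a 1.7-fold higher number from compound 1 to compound 2 (0.24 log units; within the scatter), concerns a different change and is itself within the scatter. On that basis no step beyond the scatter is expected in this assay in either direction, and the estimate for compound 3 is 22000 nM, with a range from 8000 nM to 60000 nM, which would mean a step of a 1.2-fold lower number from compound 2 to compound 3 (0.07 log units; within the scatter).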

Compound 3, concentration for 50% growth inhibition: 15000 nM
Compound 3: middle estimate off by 1.5-fold (0.17 log units), on the high side; the range from low to high includes it.
By their numbers in this assay, from the lowest: compounds 1, 3 and 2 (each within the scatter of the next).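

With bromo at this aromatic carbon, three substituents can now be compared in this assay and neither a 1.7-fold lower number from compound 2 to compound 3 (0.24 log units; within the scatter) nor no change at the digits printed from compound 1 to compound 3 (within the scatter) lies beyond the scatter. Hydrogen, methyl and bromo therefore cannot be told apart at this position on these numbers, whereas the earlier pair covered only the exchange of hydrogen for methyl. Nothing at hand bears on why these three compounds read alike.

From the compounds shown here alone, whether an amine or a longer alkyl chain on this aromatic carbon would give a step beyond the scatter remains open. Also open, going by these compounds, is how the read-out would respond if a carboxylic acid replaced the methyl ester on the shared core.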